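High Inhibition Kept Across a Hydroxamic Acid Series

The source may hold more compounds than are shown below. What is called first, only, known or untested is meant among the compounds shown, and "the series" means these compounds.

Measured compounds:
- compound 1 `CNC(=O)CCCCCCCn1nc(-c2cnc3[nH]ccc3c2)c2c(N)ncnc21`: 100%
- compound 2 `Nc1ncnc2c1c(-c1cnc3[nH]ccc3c1)nn2CCCCCCCCC(=O)NO`: 99.2%
- compound 3 `Nc1nc2cc(-c3nn(CCCCCCCCCC(=O)NO)c4ncnc(N)c34)ccc2o1`: 98.2%

In an assay on isolated protein for inhibition of protein deacetylase HDAC6 (Homo sapiens), with a stated time of 15 min, tested at 1 uM (a lower number here means less inhibition, a higher number more inhibition at the concentration tested (going by the name of the read-out)), compound 3 gives 98.2%, the lowest of the three numbers, yet its gaps to compound 2 and to compound 1 both lie within the scatter, so the three cannot be ranked. Within the data shown here, the one measured step, a number 0.8 percentage points lower from compound 1 to compound 2 (within the scatter), shows that a sizeable change at the chain end left the read-out unchanged. Compound 4 `Nc1ncnc2c1c(-c1cnc3[nH]ccc3c1)nn2CCCCCCCCCC(=O)NO` is not yet measured; it differs from compound 3 by a group of 9 heavy atoms (7 carbon, 2 nitrogen; one five-membered aromatic ring with 1 hetero atom, one six-membered aromatic ring with 1 hetero atom) in place of a group of 10 heavy atoms (7 carbon, 2 nitrogen, 1 oxygen; one five-membered aromatic ring with 2 hetero atoms, one six-membered aromatic ring of carbon only), on an aromatic carbon. Among the measured compounds shown here, no measured step concerns this aromatic exchange, so the expectation rests only on the fact that every measured number in this assay is high; the same chain end as in compound 4 is carried by compound 2, and in this assay compound 2 gives 99.2%. A step of a number 0.2 percentage points lower from compound 3 to compound 4 (within the scatter) is therefore expected, none beyond the scatter. Compound 4 is estimated at 98%, within 92% to 100%.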

Compound 4, a percentage reported as inhibition, at one concentration (the size of the read-out at that concentration, not a potency): 98.3%
Estimate against measurement, compound 4: 0.3 percentage points below; the range from low to high includes it.
By their numbers in this assay, from the lowest: compounds 3, 4, 2 and 1 (each within the scatter of the next).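

In this assay, the step at the aromatic carbon is a number 0.1 percentage points higher from compound 3 to compound 4 (within the scatter), so the group of 9 heavy atoms and 2-amino-1,3-benzoxazol-5-yl cannot be told apart at this one concentration. At the chain end, (hydroxycarbamoyl)methyl in place of hydroxycarbamoyl gives a number 0.9 percentage points lower from compound 2 to compound 4 (within the scatter) and 2-(hydroxycarbamoyl)ethyl in place of methylcarbamoyl gives a number 1.7 percentage points lower from compound 1 to compound 4 (within the scatter), so neither change separates these compounds either. Nothing measured here explains why these changes leave the read-out unmoved.

All four compounds sit so near the top of this read-out that real differences in potency could lie hidden, and a single concentration cannot reveal them. From the compounds shown here alone, it also remains open whether a carboxylic acid or a primary amine at the chain end, or a much shorter chain, would keep this level of inhibition.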